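The source may hold more compounds than are shown below. What is called first, only, known or untested is meant among the compounds shown, and "the series" means these compounds.

Measured compounds:
Compound 1 `FC(F)(F)Oc1ccc(-c2nc3cnc(Nc4ccccn4)cc3[nH]2)cc1` — in a physicochemical assay for solubility, using the shake flask method, measured as kinetic solubility, with a stated time of 20 h, at pH 2 (a lower number here means a less soluble compound, a higher number a more soluble compound), compound 1 gives 26000 nM.
Compound 2 `Fc1ccc(-c2nc3cnc(Nc4cc(C(F)(F)F)ccn4)cc3[nH]2)cc1F` — in this assay compound 2 gives only a limit, < 5000 nM.

Among the measured compounds shown here, compound 2 therefore stands at the limit of < 5000 nM in this assay, at which 1 of the 2 values shown sits, and no number is known for it; its true solubility lies somewhere under that limit, with compound 1 the only compound here reported with a value. Compound 3 `Fc1ccnc(Nc2cc3[nH]c(-c4ccc(F)c(F)c4)nc3cn2)c1` is not yet measured. It differs from compound 2 in one place: fluoro in place of trifluoromethyl on an aromatic carbon. No measured step of this kind is available among these compounds, so the direction rests on expectation alone. The step of a number no lower from compound 2 to compound 3 (the limit leaves the size open) is expected to be small, at most modestly upward, and may not rise beyond the scatter. Compound 3 is estimated at 5000 nM, within a range from 1500 nM to 15000 nM, with a real chance that this assay again returns only a limit.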

Compound 3, solubility: 166000 nM
Compound 3: middle estimate off by 33-fold (1.52 log units), on the low side, and the stated range ends below it.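

In this assay, fluoro in place of trifluoromethyl on an aromatic carbon, opposite the ring nitrogen, comes with an at least 33-fold higher number from compound 2 to compound 3 (1.52 log units; beyond the scatter). Among the compounds shown here, this is the first measured step at this position, and it shows that one change of substituent there, with no ring and no hydrogen-bond donor or acceptor leaving or entering, can move the read-out well beyond the scatter. The true size of the step stays open at its upper end, because compound 2 carries a limit and not a number: the limit of < 5000 nM in this assay, at which 1 of the 3 values shown sits.

The compounds shown leave open how an amine, a methoxy group or a nitrile on this same carbon would read. They also leave open why the number moves so far, and whether the same exchange elsewhere on the shared core would give a step of similar size.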